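From ethoxy to hydroxy on the aromatic ring

This account rests on a few compounds, and the source may have more. Where it says the series, first, only, none or still open, it means among the compounds named here.

Within the data shown here, in a functional assay on MDA-MB-231 cells (Homo sapiens) for antiproliferative activity, read by MTT assay, with a stated time of 48 h (a higher number here means a weaker inhibitor of growth, a lower number a stronger inhibitor of growth), compound 3 `CCOc1cccc(C2=NN(C(=O)OC)C(c3cc(OC)c(OC)c(OC)c3)C2)c1` gives 190 nM, the lowest number of the three measured so far. Compound 1 `COC(=O)N1N=C(c2cccc(O)c2)CC1c1cc(OC)c(OC)c(OC)c1` gives 740 nM. Compound 2 `CCCOC(=O)N1N=C(c2cccc(O)c2)CC1c1cc(OC)c(OC)c(OC)c1` gives 10000 nM.

The next compound, compound 4 `COC(=O)N1N=C(c2ccc(O)cc2)CC1c1cc(OC)c(OC)c(OC)c1`, carries 4-hydroxyphenyl in place of 3-ethoxyphenyl on a carbon with a double bond to nitrogen. The closest guide is the modest step of a 3.9-fold lower number from compound 1 to compound 3 (0.59 log units; beyond the scatter), which puts ethyl in place of hydrogen on an oxygen on an aromatic ring. Compound 4 has no such ethyl, so that step suggests its number will lie above that of compound 3, perhaps near that of compound 1. However, compound 4 differs from compound 1 in where the hydroxy group sits on the aromatic ring, and no measured pair shows what such a shift does. Among the measured compounds shown here, the large step of a 14-fold higher number from compound 1 to compound 2 (1.13 log units; beyond the scatter) concerns the methoxycarbonyl group, which compound 4 keeps, so it shows only that one change can move this number a long way. A higher number is therefore expected, with an estimated 6.3-fold higher number from compound 3 to compound 4 (0.80 log units; beyond the scatter). For compound 4 the estimate is 1200 nM, with an expected range of 250 nM to 6000 nM.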

Compound 4, concentration for 50% growth inhibition: 7150 nM
Beside the measured number, compound 4's estimate is 6.0-fold (0.78 log units) below it; the whole stated range lies below it.
By their numbers in this assay, from the lowest: compound 3; then compound 1; then compounds 4 and 2 (each within the scatter of the next).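

In this assay, among these compounds, shifting the hydroxy group alone, with 4-hydroxyphenyl in place of 3-hydroxyphenyl, gives a 9.7-fold higher number from compound 1 to compound 4 (0.99 log units; beyond the scatter) on the same core, so where the group sits on this aromatic ring matters as well as which group it is, something no earlier pair could show. The full change gives a 38-fold higher number from compound 3 to compound 4 (1.58 log units; beyond the scatter) and joins two edits, the loss of the ethyl and the shift of the oxygen, with compound 1 carrying only the first of them, so both edits in this series go towards weaker growth inhibition. No measurement at hand explains why the shift has this effect.

The compounds shown leave open whether the ethoxy group would respond to the same shift as the hydroxy group did, since only the hydroxy group appears in both places on the ring. They also leave open how far this position tolerates other groups, such as an amine, a carboxylic acid or a longer chain like butoxy in place of the ethoxy group of compound 3.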